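Working notes: cyclohexyl for isobutyl, one untested step

This account rests on a few compounds, and the source may have more. Where it says the series, first, only, none or still open, it means among the compounds named here.

Measured so far:
compound 1, `CCCCCCC[C@H]1C[C@H](Cl)CCN1S(=O)(=O)c1ccc(C)cc1`: > 100000 nM
compound 2, `Cc1ccc(S(=O)(=O)N2CCC(Cl)=CC2CC(C)C)cc1`: 35000 nM

In a functional assay on A2780 cells (Homo sapiens) for antiproliferative activity, read by sulforhodamine B assay, with a stated time of 48 h (on this read-out higher numbers stand for weaker inhibition of growth and lower numbers for stronger inhibition of growth), compound 1 gives only a limit, > 100000 nM. For the measured compounds named here, compound 2 gives the single real number of the set in this assay, 35000 nM. The other entry is a limit, (the limit of > 100000 nM in this assay, at which 1 of the 2 values shown sits). Compound 3, `Cc1ccc(S(=O)(=O)N2CCC(Cl)=CC2C2CCCCC2)cc1`, is not yet measured. It differs from compound 2 by cyclohexyl in place of isobutyl on a saturated ring carbon. Going by the values given here, no measured pair follows this change, so no step size is known from the data; a step within the usual scatter is expected, direction open. Compound 3 is expected to give 25000 nM in this assay, between 6000 nM and 100000 nM, an expected step of a 1.4-fold lower number from compound 2 to compound 3 (0.15 log units; within the scatter).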

Compound 3, concentration for 50% growth inhibition: 39000 nM
Compound 3: middle estimate off by 1.6-fold (0.19 log units), on the low side; the measured number falls inside the stated range.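

In this assay, cyclohexyl in place of isobutyl on a saturated ring carbon gives a 1.1-fold higher number from compound 2 to compound 3 (0.05 log units; within the scatter). For the compounds shown here, this is the first step that can be read at this position, and it shows that the assay does not separate these two carbon-only groups there. No measured property in the data bears on this step.

From the compounds shown here alone, it remains open whether a group carrying an amine, or a phenyl group, on this saturated ring carbon would move the number beyond the scatter. Going by these compounds, whether a different group in place of the chloro group would do so also remains open.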